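Nitro in place of benzyloxy: from compound 2 to compound 3

This account rests on a few compounds, and the source may have more. Where it says the series, first, only, none or still open, it means among the compounds named here.

These notes cover a small series tested in a functional assay on SK-OV-3 cells (Homo sapiens) for inhibition, read by CCK-8 assay, with a stated time of 70 h; a lower number here means a stronger inhibitor, a higher number a weaker inhibitor. Compound 1 `O=C(O)c1cccc(COc2ccc(OCCOCCNC3CCCC3)cc2)c1` gives only a limit of the assay, > 100000 nM. Going by the values given here, compound 2 `c1ccc(COc2ccc(COc3ccc(OCCOCCNC4CCCC4)cc3)cc2)cc1` gives 10000 nM, the only actual number so far. Among the compounds with values here, its standing therefore cannot be judged against a second number, and the series offers no measured step that changes a single place.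

Compound 3 `O=[N+]([O-])c1ccc(COc2ccc(OCCOCCNC3CCCC3)cc2)cc1` carries nitro in place of benzyloxy on an aromatic carbon, para to a large group: nitro in place of benzyloxy on an aromatic carbon. Within the data shown here, the data hold no direct precedent for this change, so what follows is an expectation with wide margins. Weaker inhibition is expected in this assay, by a moderate step that probably lies beyond the usual scatter, with compound 2 at 10000 nM as the only numerical anchor. The expected change is a 3.0-fold higher number from compound 2 to compound 3 (0.48 log units; beyond the scatter). A result reported only as a limit remains possible. For compound 3 the estimated value is 30000 nM, with an expected range of 10000 nM to 100000 nM.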

Compound 3, half-maximal inhibitory concentration: 20300 nM
Compound 3: the middle estimate sits 1.5-fold (0.17 log units) above what was measured; the range from low to high includes it.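

In this assay, this aromatic carbon, para to a large group, now has its first measured step, a 2.0-fold higher number from compound 2 to compound 3 (0.31 log units; beyond the scatter), and it is modest: benzyloxy leaves with its six-membered aromatic ring, nitro enters with no ring, and compound 3 still gives an actual number rather than a limit. The second step, an at least 4.9-fold lower number from compound 1 to compound 3 (0.69 log units; beyond the scatter), has 4-nitrophenyl in place of 3-carboxyphenyl on a saturated chain carbon bound to an oxygen on an aromatic ring. Compound 1 is reported only as a limit of the assay, so this second step fixes a bound and not a size: the limit of > 100000 nM in this assay, at which 1 of the 3 values shown sits.

As far as these compounds go, how other groups on this aromatic carbon compare remains open: an amine, a methoxy group or a chlorine atom there would show whether the step seen with nitro is particular to nitro. The chain carrying the amine is the same in all three compounds, so a longer chain at that end has no reading yet in this assay.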